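The source may hold more compounds than are shown below. What is called first, only, known or untested is meant among the compounds shown, and "the series" means these compounds.

Working notes on the series. Compound 1 `CC(C)CCn1nc(CC(C)(C)C)c(O)c(C2=NS(=O)(=O)c3cc(NS(C)(=O)=O)ccc3N2)c1=O` carries the shared core with an isopentyl group and a neopentyl group. In an ADME assay on Huh-7 cells (Homo sapiens) for cytotoxicity, with a stated time of 72 h (a higher number here means that more compound is tolerated, a lower number that less compound is tolerated), compound 1 gives > 1000 nM, which is a limit of the assay and not a number. Within the data shown here, compound 2 `CC(C)(C)CCn1nc(CC(C)(C)C)c(O)c(C2=NS(=O)(=O)c3cc(NS(C)(=O)=O)ccc3N2)c1=O` is the one other measured member. In this assay compound 2 gives > 1000 nM, again a limit of the assay. Among the measured compounds shown here, the single measured step, a step that the two limits leave unreadable from compound 1 to compound 2, therefore cannot be read in size or direction, since (the limit of > 1000 nM in this assay, at which 2 of the 2 values shown sit). Compound 3 `CC(C)CCn1nc(C(C)(C)C)c(O)c(C2=NS(=O)(=O)c3cc(NS(C)(=O)=O)ccc3N2)c1=O` is not yet measured. It differs from compound 1 by tert-butyl in place of neopentyl on an aromatic carbon. For the measured compounds named here, no measured step bears on this change in a readable way, so the only basis is where compound 1 stands, at the limit. No shift beyond the scatter is expected, and compound 3 is most likely to sit at the limit of this assay as well. Compound 3 is therefore expected to give about 2000 nM, in the range 700 nM to 6000 nM, meaning an expected step that the limit leaves unreadable from compound 1 to compound 3 that is not beyond the scatter.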

Compound 3, half-maximal cytotoxic concentration: > 17000 nM
Compound 3 ended at the assay's limit; the forecaster's own chance of this, stated with the estimate: 75%; middle value at least 8.5-fold (0.92 log units) away from the limit.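

In this assay compound 3 gives > 17000 nM, a limit of the assay and not a number. Among these compounds, with compound 1 also at a limit, no step between compound 1 and compound 3 can be read. The compounds shown leave open whether tert-butyl in place of neopentyl changes the half-maximal cytotoxic concentration at all.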